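Parallel check on the aryl swap at the ring nitrogen

A few compounds are considered here, and "the series" means these few. Any claim that something is new, unique, unknown or untested is made for them only; others in the source may bear on it.

Compound 3 `Cc1cc(=O)n(-c2ccc(Br)cc2F)nc1C(=O)Nc1ccc(Oc2ncnc3c2ccn3C)cc1` gives 33600 nM in a functional assay on HepG2 cells (Homo sapiens) for cytotoxicity, read by MTT assay, with a stated time of 72 h (a lower number here means a stronger inhibitor, a higher number a weaker inhibitor), the highest number of the three measured; compound 1 `Cc1ccc(-n2nc(C(=O)Nc3ccc(Oc4ncnc5[nH]ccc45)cc3)c(C)cc2=O)cc1` gives 7460 nM and compound 2 `Cc1cc(=O)n(-c2ccc(Br)cc2F)nc1C(=O)Nc1ccc(Oc2ncnc3[nH]ccc23)cc1` gives 3660 nM, and both of those differences from compound 3 are beyond the scatter. Compound 4 `Cc1ccc(-n2nc(C(=O)Nc3ccc(Oc4ncnc5c4ccn5C)cc3)c(C)cc2=O)cc1` is compound 3 with 4-methylphenyl in place of 4-bromo-2-fluorophenyl on an aromatic nitrogen. The step that bears on it is the matching swap in the opposite direction, a 2.0-fold lower number from compound 1 to compound 2 (0.31 log units; beyond the scatter), which was modest but beyond the scatter. For compound 3 to compound 4 the reverse is therefore expected: a modest rise in the number, of the same order as that step. The second measured step, a 9.2-fold higher number from compound 2 to compound 3 (0.96 log units; beyond the scatter), does not touch the changed group but sets the shared N-methyl background of compounds 3 and 4; its size applied to compound 1 points to much the same place. Compound 4 is thus expected to be the weakest in the set, with an estimated 1.9-fold higher number from compound 3 to compound 4 (0.29 log units; within the scatter) and a value of 65000 nM in this assay, in a range of 30000 nM to 140000 nM.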

Compound 4, half-maximal inhibitory concentration: 33800 nM
For compound 4 the middle estimate is 1.9-fold (0.28 log units) above the measured one; measured number inside the range.
By their numbers in this assay, from the lowest: compound 2; then compound 1; then compounds 3 and 4 (each within the scatter of the next).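

Moving from the 4-bromo-2-fluorophenyl to the 4-methylphenyl on the aromatic nitrogen gives a 1.0-fold higher number from compound 3 to compound 4 (0.00 log units; within the scatter), so with methyl on the core nitrogen the two aryl groups are not told apart in this assay, although they were separated on the core of compound 1. The aryl step therefore cannot be said to differ between the two cores: the same change on two cores in this assay, a 2.0-fold lower number (0.31 log units; beyond the scatter) from compound 1 to compound 2 and a 1.0-fold lower number (0.00 log units; within the scatter) from compound 4 to compound 3, 2.0-fold (0.31 log units) apart, within the scatter of two such steps. Methyl in place of hydrogen on the core nitrogen now also reads on the second aryl group, a 4.5-fold higher number from compound 1 to compound 4 (0.66 log units; beyond the scatter), and in both available pairs the number rises by amounts that agree: the same change on two cores in this assay, a 9.2-fold higher number (0.96 log units; beyond the scatter) from compound 2 to compound 3 and a 4.5-fold higher number (0.66 log units; beyond the scatter) from compound 1 to compound 4, 2.0-fold (0.31 log units) apart, within the scatter of two such steps.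

Open, on these data alone, is whether a longer chain or a chain ending in an amine on that core nitrogen would follow the methyl step. Also open, as far as these compounds go, is whether an aryl group carrying a carboxylic acid would separate from these two aryl groups on either core.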